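Notes on a fluorophenyl swap in a small series

A few compounds are considered here, and "the series" means these few. Any claim that something is new, unique, unknown or untested is made for them only; others in the source may bear on it.

Measured so far:
compound 1, `COc1ccccc1N1CCN(C[C@@H](O)COc2ccc(F)cc2)CC1`: 50.7%
compound 2, `O[C@H](COc1ccc(C(F)(F)F)cc1)CN1CCN(c2ccccc2F)CC1`: 48.9%

Both compounds were run in an assay on HEK293 cells for inhibition of Voltage-dependent T-type calcium channel subunit alpha-1G (Homo sapiens), read by patch clamp, tested at 10 uM (on this read-out lower numbers stand for less inhibition and higher numbers for more inhibition at the one concentration tested (going by the name of the read-out)), at a single concentration. Compound 2 carries the lower of the two numbers recorded in this assay; the nearest is compound 1, whose value sits within the scatter of repeated measurements, so the two cannot be told apart on this read-out. Among the compounds with values here, no pair of measured compounds differs in only one place, so no measured step within this assay is available to lean on.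

Compound 3, `O[C@H](COc1ccc(C(F)(F)F)cc1)CN1CCN(c2ccc(F)cc2)CC1`, has not been measured yet. It differs from compound 2 in one place: 4-fluorophenyl in place of 2-fluorophenyl on an amine nitrogen in a ring. Neither measured compound informs this particular change, since compound 1 and compound 2 differ from each other at several places at once. The expected step is a number 1.1 percentage points higher from compound 2 to compound 3 (within the scatter), which amounts to no change beyond the scatter of this assay. Compound 3 is expected to give 50% in this assay, with an estimated range from 30% to 70%.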

Compound 3, a percentage reported as inhibition, at one concentration (the size of the read-out at that concentration, not a potency): 59.2%
For compound 3 the middle estimate is 9.2 percentage points below the measured one, within the range that was stated.
By their numbers in this assay, from the lowest: compounds 2, 1 and 3 (each within the scatter of the next, the first and the last beyond it).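

In this assay, within the data shown here, the exchange of 2-fluorophenyl for 4-fluorophenyl on an amine nitrogen in a ring gives a number 10.3 percentage points higher from compound 2 to compound 3 (beyond the scatter) and provides the first reading of a change at one place only. The groups that leave and enter match in heavy atoms and ring count, so the modest step tracks only where the fluorine sits on the aromatic ring, which shows that this position is not indifferent to that placement in this background. Nothing at hand bears on the reason for the step.

From the compounds shown here alone, the step rests on a single pair with the trifluoromethyl-bearing end held fixed, so it remains open whether the same exchange would hold with the other end of the molecule as in compound 1. Also open, going by these compounds, is how unsubstituted phenyl, a chlorophenyl or a pyridyl group at this same place would compare with 4-fluorophenyl, and whether the step would persist as a difference in potency beyond the one concentration tested.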